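Cinnamanilide stilbenes against breast cancer cells: chloro for fluoro

The source may report more compounds than this note shows. Statements on the series, on what has been measured and on what is new or still open speak of the compounds shown alone.

Measured compounds:
compound 1, `COc1cc(/C=C/c2ccc(NC(=O)/C=C/c3ccc(OC)c(OC)c3)cc2)cc(OC)c1`, 7740 nM
compound 2, `COc1cc(/C=C/c2ccc(NC(=O)/C=C/c3ccc(C#N)cc3)cc2)cc(OC)c1`, 7740 nM
compound 3, `COc1cc(/C=C/c2ccc(NC(=O)/C=C/c3cccc(F)c3)cc2)cc(OC)c1`, 17300 nM

All three compounds share one core and were tested in a functional assay on MDA-MB-231 cells (Homo sapiens) for inhibition, read by MTT assay, with a stated time of 48 h; a higher number here means a weaker inhibitor, a lower number a stronger inhibitor. Compound 1 gives 7740 nM and compound 2 gives 7740 nM; the two differ only in the aryl group on the double-bonded chain carbon and show no change at the digits printed from compound 1 to compound 2 (within the scatter). Compound 3, which carries a 3-fluorophenyl at that place, gives 17300 nM and stands highest of the three numbers, with a 2.2-fold higher number from compound 1 to compound 3 (0.35 log units; beyond the scatter) and a 2.2-fold higher number from compound 2 to compound 3 (0.35 log units; beyond the scatter) setting it apart from both others beyond the scatter.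

The next compound, compound 4 with structure `COc1cc(/C=C/c2ccc(NC(=O)/C=C/c3ccc(Cl)cc3)cc2)cc(OC)c1`, differs from compound 3 in the same region: 4-chlorophenyl in place of 3-fluorophenyl on a double-bonded chain carbon bound to a double-bonded chain carbon. Both measured steps into compound 3 bear on this change, since each replaced the 3-fluorophenyl partner with a different aryl and each gave a number lower than compound 3 by a modest margin. A chloro aryl is a third variant at the same place, and on these three numbers a modest return toward the values of compound 1 and compound 2 is the most reasonable expectation. Compound 4 is therefore estimated at 9500 nM, within 4500 nM to 20000 nM, which corresponds to an expected step of a 1.8-fold lower number from compound 3 to compound 4 (0.26 log units; within the scatter) from compound 3.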

Compound 4, half-maximal inhibitory concentration: 14100 nM
For compound 4 the middle estimate is 1.5-fold (0.17 log units) below the measured one; measured number inside the range.
By their numbers in this assay, from the lowest: compounds 1, 2, 4 and 3 (each within the scatter of the next, the first and the last beyond it).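

In this assay, 4-chlorophenyl in place of 3-fluorophenyl gives a 1.2-fold lower number from compound 3 to compound 4 (0.09 log units; within the scatter), so these two aryl groups are not told apart at this place on a double-bonded chain carbon. Compound 4 is equally unseparated from the other two partners, with chloro in place of cyano on an aromatic carbon giving a 1.8-fold higher number from compound 2 to compound 4 (0.26 log units; within the scatter) and 4-chlorophenyl in place of 3,4-dimethoxyphenyl giving a 1.8-fold higher number from compound 1 to compound 4 (0.26 log units; within the scatter) as the reading. Going by these compounds alone, compound 4 therefore joins neither side of the gap that the earlier steps showed: it lies within the scatter of all three other compounds, and compound 3 remains separated only from compound 1 and compound 2, by modest steps.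

Because the halogen and its ring position change together from compound 3 to compound 4, the compounds shown cannot assign the result to either one, and it remains open whether an amine or a carboxylic acid on this aryl ring would give a number outside the scatter of these four. Nothing given here accounts for these numbers.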